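This account rests on a few compounds, and the source may have more. Where it says the series, first, only, none or still open, it means among the compounds named here.

Three compounds of the series have been run so far in a functional assay on WM 266-4 cells (Homo sapiens) for antiproliferative activity, read by MTT assay, with a stated time of 48 h; a lower number here means a stronger inhibitor, a higher number a weaker inhibitor. Compound 1 `O=C(Nc1cc(-c2ccccc2)[nH]n1)c1cncc(Br)c1` gives 6880 nM in this assay. Compound 2 `O=C(Nc1cc(-c2ccccc2)[nH]n1)c1ccc(Br)nc1` gives 6730 nM in this assay. Compound 3 `O=C(Nc1cc(-c2ccc(Br)cc2)[nH]n1)c1cncc(Br)c1` gives 8230 nM in this assay, with all three readings lying within the usual scatter of one another. Compound 4 `O=C(Nc1cc(-c2ccc(Br)cc2)[nH]n1)c1ccc(Br)nc1` has not yet been measured.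

The change from compound 3 to compound 4 is 6-bromopyridin-3-yl in place of 5-bromopyridin-3-yl on a carbonyl carbon. The same change has been made once before, from compound 1 to compound 2, as 6-bromopyridin-3-yl in place of 5-bromopyridin-3-yl on a carbonyl carbon, where it gave a 1.0-fold lower number from compound 1 to compound 2 (0.01 log units; within the scatter). The place of the change is described in the same words in both pairs, so the two changes count as the same change; the cores on which it is made differ by bromo in place of hydrogen on an aromatic carbon, which itself gave a 1.2-fold higher number from compound 1 to compound 3 (0.08 log units; within the scatter).

From compound 3 to compound 4 a step of about a 1.0-fold lower number from compound 3 to compound 4 (0.01 log units; within the scatter) is expected in this assay, resting on the earlier 1.0-fold lower number from compound 1 to compound 2 (0.01 log units; within the scatter), which was within the scatter. Compound 4 is accordingly estimated at 8000 nM in this assay, with a likely range of 4000 nM to 16000 nM.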

Compound 4, half-maximal inhibitory concentration: 8560 nM
Beside the measured number, compound 4's estimate is 1.1-fold (0.03 log units) below it; low and high end bracket the measured number.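

In this assay, 6-bromopyridin-3-yl in place of 5-bromopyridin-3-yl on a carbonyl carbon gives a 1.0-fold higher number from compound 3 to compound 4 (0.02 log units; within the scatter), in agreement with the earlier step on the core of compound 1: the same change on two cores in this assay, a 1.0-fold lower number (0.01 log units; within the scatter) from compound 1 to compound 2 and a 1.0-fold higher number (0.02 log units; within the scatter) from compound 3 to compound 4, 1.1-fold (0.03 log units) apart, within the scatter of two such steps. Bromo in place of hydrogen on an aromatic carbon gives a 1.3-fold higher number from compound 2 to compound 4 (0.10 log units; within the scatter), which also agrees with its earlier step: the same change on two cores in this assay, a 1.2-fold higher number (0.08 log units; within the scatter) from compound 1 to compound 3 and a 1.3-fold higher number (0.10 log units; within the scatter) from compound 2 to compound 4, 1.1-fold (0.03 log units) apart, within the scatter of two such steps. Among these compounds, both changes therefore carry from one core to the other in these four compounds, but every step lies within the scatter, so this shows only that neither change moved the number on either core, not that a step of measurable size would carry over in the same way.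

Going by these compounds, it remains open whether any replacement of the bromo groups, such as an amine or a carboxylic acid, would shift the number beyond the scatter. On these data alone, it is also open whether such a step would hold on both cores.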